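Compound 2 to compound 4: a chlorophenyl exchange

This account rests on a few compounds, and the source may have more. Where it says the series, first, only, none or still open, it means among the compounds named here.

This account follows one change in a set of three measured compounds and one unmeasured compound. In a functional assay on MGC-803 cells (Homo sapiens) for antiproliferative activity, read by MTT assay, with a stated time of 72 h (a lower number here means a stronger inhibitor, a higher number a weaker inhibitor), compound 1 `CCCSc1nc(N/N=C(\C)c2ccccc2O)c2nnn(Cc3ccco3)c2n1` gives 4760 nM. In this assay compound 3 `C#CCSc1nc(N/N=C(\C)c2ccccc2O)c2nnn(Cc3ccccc3)c2n1` gives 3820 nM, a value that sits within the usual scatter of that of compound 1, so the two are not ranked against each other here. Compound 2 `CCCSc1nc(N/N=C/c2ccc(Cl)cc2)c2nnn(Cc3ccccc3)c2n1` is different: in this assay compound 2 returns only a limit, > 64000 nM, and no number is known for it. Among the compounds with values here, it is the one value among the three that sits at the limit of > 64000 nM in this assay, at which 1 of the 3 values shown sits.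

Compound 4 `CCCSc1nc(N/N=C/c2cccc(Cl)c2)c2nnn(Cc3ccccc3)c2n1` differs from compound 2 by 3-chlorophenyl in place of 4-chlorophenyl on a carbon with a double bond to nitrogen. Within the data shown here, no step between two measured compounds is available to size this change, so the expectation rests on compound 2 alone. The step of an at least 1.0-fold lower number from compound 2 to compound 4 (0.02 log units; that floor lies within the scatter) is expected to be small and of no certain direction. In this assay compound 4 is therefore estimated at about 60000 nM, with a range of 15000 nM to 200000 nM, and a real chance that only a limit is reported again.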

Compound 4, half-maximal inhibitory concentration: > 64000 nM
Compound 4 gave a limit, no number; the forecaster's own chance of this, stated with the estimate: 60%; middle value at least 1.0-fold (0.02 log units) from the limit.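

In this assay compound 4 returns only a limit, > 64000 nM, as compound 2 also does, so no step can be read between compound 2 and compound 4. The compounds shown leave open whether 3-chlorophenyl or 4-chlorophenyl gives the lower number.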